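Dichlorophenyl Replaces Dimethylphenyl on the Triazole Nitrogen

This account rests on a few compounds, and the source may have more. Where it says the series, first, only, none or still open, it means among the compounds named here.

Compound 3 `Cc1ccc(C)c(-n2nncc2CN2C(=O)C3(C(C#N)=C(N)Oc4c3c3nc5ccccc5nc3c3ccccc43)c3ccccc32)c1` sits at a limit in a functional assay on A549 cells (Homo sapiens) for antiproliferative activity, read by MTT assay, with a stated time of 48 h; a lower number here means a stronger inhibitor, a higher number a weaker inhibitor: its value of > 50000 nM is a limit of the assay, not a number. Compound 4 `N#CC1=C(N)Oc2c(c3nc4ccccc4nc3c3ccccc23)C12C(=O)N(Cc1cnnn1-c1ccc(Cl)c(Cl)c1)c1ccccc12` keeps the shared core with one change: 3,4-dichlorophenyl in place of 2,5-dimethylphenyl on an aromatic nitrogen. Within the data shown here, two measured steps bear on this. Compound 1 `N#CC1=C(N)Oc2c(c3nc4ccccc4nc3c3ccccc23)C12C(=O)N(Cc1cnnn1-c1cccc(Cl)c1)c1ccccc12` carries a 3-chlorophenyl and gives 32600 nM, and the step of an at least 1.5-fold higher number from compound 1 to compound 3 (0.18 log units; that floor lies within the scatter) shows the dimethylphenyl to be the weaker group by at least that much. Compound 2 `N#CC1=C(N)Oc2c(c3nc4ccccc4nc3c3ccccc23)C12C(=O)N(Cc1cnnn1-c1cccc(Br)c1)c1ccccc12` with a 3-bromophenyl returns a limit, > 50000 nM. The step of an at least 1.5-fold higher number from compound 1 to compound 2 (0.18 log units; that floor lies within the scatter) and the fact that the limit of > 50000 nM in this assay, at which 2 of the 3 values shown sit, leave the effect of a second chloro unreadable. Compound 4 is therefore expected near 40000 nM, between 15000 nM and 60000 nM, a step of an at least 1.2-fold lower number from compound 3 to compound 4 (0.09 log units; that floor lies within the scatter) that may well stay at the limit.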

Compound 4, half-maximal inhibitory concentration: > 50000 nM
Compound 4: only a limit was reported; the forecaster's own chance of this, stated with the estimate: 50%; at least 1.2-fold (0.09 log units) between middle value and limit.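

Compound 4 sits at a limit, > 50000 nM, and this is not a number. A second chloro on the 3-chlorophenyl gives an at least 1.5-fold higher number from compound 1 to compound 4 (0.18 log units; that floor lies within the scatter), so this added chloro brings no visible gain in strength. The steps from compound 2 and compound 3 to compound 4 cannot be read: the limit of > 50000 nM in this assay, at which 3 of the 4 values shown sit.

From the compounds shown here alone, how far compound 2, compound 3 and compound 4 differ from one another stays open. Also open, going by these compounds, is whether an amine or a carboxylic acid on the phenyl ring would give a value clear of the limit.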